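Urea series on a shared core: cytotoxicity working notes

The source may report more compounds than this note shows. Statements on the series, on what has been measured and on what is new or still open speak of the compounds shown alone.

The series shares the core of compound 1 `Cc1cc(NC(=O)Nc2ccc(C)c(Cl)c2)c2ccccc2n1`, a urea linking it to a second aromatic ring bearing varied groups. In an ADME assay on HepG2 cells (Homo sapiens) for cytotoxicity, with a stated time of 72 h (on this read-out higher numbers stand for an effect only at larger amounts of compound and lower numbers for an effect already at smaller amounts), compound 1 gives > 25000 nM, which is a limit of the assay and not a number. Compound 2 `Cc1cc(NC(=O)Nc2ccc([N+](=O)[O-])c(C(F)(F)F)c2)c2ccccc2n1` carries nitro and trifluoromethyl groups; in this assay compound 2 gives > 25000 nM, again a limit. Compound 3 `Cc1cc(NC(=O)Nc2ccc(C(=O)O)cc2)c2ccccc2n1` carries a carboxy group; in this assay compound 3 gives > 25000 nM, also a limit. Compound 3 therefore stands where every measured member stands, at the limit of > 25000 nM in this assay, at which 3 of the 3 values shown sit, and no compound shown separates from another. Compound 4 `Cc1ccc(NC(=O)Nc2cc(C)nc3ccccc23)cc1` is not yet measured; the change from compound 3 is methyl in place of carboxy on an aromatic carbon. Among the compounds with values here, no step between measured compounds is available. Because all values sit at the limit of > 25000 nM in this assay, at which 3 of the 3 values shown sit, the expected step is a step that the limit leaves unreadable from compound 3 to compound 4, none beyond the scatter, with the result most likely reported again as a limit. Compound 4 is expected at 30000 nM, ranging from 12000 nM to 80000 nM.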

Compound 4, half-maximal effective concentration: > 25000 nM
Compound 4: no number, only a limit; the forecaster's own chance of this, stated with the estimate: 80%; the middle value is on the limit's open side.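

In this assay compound 4 gives > 25000 nM, a limit of the assay and not a number. Within the data shown here, no step from compound 3 or compound 1 to compound 4 can be read. Left open is whether any group on the second aromatic ring changes the read-out, with every compound shown at the same limit: the limit of > 25000 nM in this assay, at which 4 of the 4 values shown sit.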